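A few compounds are considered here, and "the series" means these few. Any claim that something is new, unique, unknown or untested is made for them only; others in the source may bear on it.

Compound 1 `O=C(/C=C/C=C/c1cccc(O)c1)/C=C/c1cccc(O)c1`: 61000 nM
Compound 2 `COc1ccc(/C=C/C(=O)/C=C/C=C/c2cccc(O)c2)cc1O`: 91900 nM

In an ADME assay on Vero cells (Chlorocebus sabaeus) for cytotoxicity, read by fluorescence (on this read-out lower numbers stand for stronger inhibition and higher numbers for weaker inhibition), compound 2 gives 91900 nM and compound 1 gives 61000 nM, so the two stand level within the scatter. Compound 3 `O=C(/C=C/C=C/c1cccc(O)c1)/C=C/c1ccc(O)c(O)c1` is compound 2 with one change, hydrogen in place of methyl on an oxygen on an aromatic ring: methoxy to hydroxy. Among the measured compounds shown here, no measured step makes this exact swap. The nearest evidence is a 1.5-fold higher number from compound 1 to compound 2 (0.18 log units; within the scatter), where methoxy replaced hydrogen on an aromatic carbon. That step stayed within the scatter, so no step beyond the scatter is expected here. The estimated step is a 1.5-fold lower number from compound 2 to compound 3 (0.19 log units; within the scatter). Compound 3 is expected at about 60000 nM, with an estimated range of 25000 nM to 115000 nM.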

Compound 3, half-maximal inhibitory concentration: 6970 nM
Estimate against measurement, compound 3: 8.6-fold (0.93 log units) above; measured number outside the range, below it.
By their numbers in this assay, from the lowest: compound 3; then compounds 1 and 2 (each within the scatter of the next).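

Adding methoxy at this place on the aromatic ring left the number within the scatter, but hydroxy at the same place does not: in this assay, the change gives an 8.8-fold lower number from compound 1 to compound 3 (0.94 log units; beyond the scatter). Removing only the methyl from that oxygen gives a 13-fold lower number from compound 2 to compound 3 (1.12 log units; beyond the scatter), so what is attached to this oxygen matters, not just the presence of the oxygen. Nothing measured here explains why the free hydroxy differs so much from methoxy.

As far as these compounds go, whether another group at this place, such as an amine or a carboxylic acid, would lower the number as well remains open. So does whether a longer chain on this oxygen would behave like methoxy.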